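Swapping an Amide Side Chain for a Short Alcohol

This account rests on a few compounds, and the source may have more. Where it says the series, first, only, none or still open, it means among the compounds named here.

Of the compounds shown here, three sharing one core have been measured in an assay on the whole organism (plasma, strain Sprague-Dawley) for inhibition of Dipeptidyl peptidase 4 (Rattus norvegicus), with a stated time of 6 h, at a dose of 1 mg/kg by the oral route; a lower number here means less inhibition, a higher number more inhibition at the dose given (going by the name of the read-out). Compound 1 `CN(C)C(=O)C[C@@H]1CN[C@H](C(=O)N2CCC[C@H]2C#N)C1` gives 66%, compound 2 `CCCNC(=O)[C@@H]1CN[C@H](C(=O)N2CCC[C@H]2C#N)C1` gives 59%, and compound 3 `N#C[C@@H]1CCCN1C(=O)[C@@H]1C[C@H](C(=O)N2CCCCC2)CN1` gives 84%. Compound 2 sits lowest of the three, with compound 1 nearest (a number 7 percentage points lower from compound 1 to compound 2 (within the scatter)) and compound 3 furthest (a number 25 percentage points higher from compound 2 to compound 3 (beyond the scatter)).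

Compound 4 `N#C[C@@H]1CCCN1C(=O)[C@@H]1C[C@H](CCO)CN1` differs from compound 2 in one place: 2-hydroxyethyl in place of propylcarbamoyl on a saturated ring carbon. The change removes the amide on that ring carbon altogether and leaves a much smaller group. The measured steps show that reshaping this side chain shifts the read-out little or only modestly, so for compound 4 the expected step is a number 4 percentage points lower from compound 2 to compound 4 (within the scatter). Compound 4 is therefore estimated at 55%, within a range from 30% to 80%.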

Compound 4, a percentage reported as inhibition, in the whole organism at one dose (the size of the read-out at that dose, not a potency): 64%
Compound 4: the middle estimate sits 9 percentage points below what was measured; low and high end bracket the measured number.
By their numbers in this assay, from the lowest: compounds 2, 4 and 1 (each within the scatter of the next); then compound 3.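

In this assay the propylcarbamoyl group on this ring carbon gives way to the smaller 2-hydroxyethyl, leaving no amide there, and the change stays within the scatter (a number 5 percentage points higher from compound 2 to compound 4 (within the scatter)). Hydroxymethyl in place of dimethylcarbamoyl on the chain carbon reads the same way (a number 2 percentage points lower from compound 1 to compound 4 (within the scatter)), so in these two pairs the read-out does not depend on keeping the amide. No measurement available here explains this.

From the compounds shown here alone, whether an amine or a carboxylic acid on this ring carbon would hold the number stays open. So does whether a longer alcohol chain could reach the level of compound 3 (84%).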